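The source may report more compounds than this note shows. Statements on the series, on what has been measured and on what is new or still open speak of the compounds shown alone.

Compound 1, `CN(C)c1ncnc2c1c(-c1ccoc1)cn2[C@@H]1O[C@H](CO)[C@@H](O)[C@H]1O`: in a functional assay on CEM-DNR-bulk cells (Homo sapiens), read by MTT assay, with a stated time of 72 h (a higher number here means a weaker inhibitor, a lower number a stronger inhibitor), compound 1 gives > 20000 nM, a limit rather than a number.
Compound 2, `CNc1ncnc2c1c(-c1cccs1)cn2[C@@H]1O[C@H](CO)[C@@H](O)[C@H]1O`: in this assay compound 2 gives > 20000 nM, again only a limit.

Every value shown so far sits at the limit of > 20000 nM in this assay, at which 2 of the 2 values shown sit, so compound 2 stands nowhere measurable on the scale. Compound 3, `CN(C)c1ncnc2c1c(-c1cccs1)cn2[C@@H]1O[C@H](CO)[C@@H](O)[C@H]1O`, differs from compound 2 by methyl in place of hydrogen on a nitrogen on an aromatic ring. No step between measured compounds is shown, and nothing in the numbers points to a change beyond the usual scatter in this assay. Compound 3 is therefore expected at 30000 nM, somewhere between 10000 nM and 100000 nM. The expected change is a step that the limit leaves unreadable from compound 2 to compound 3, most likely again showing only as a limit.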

Compound 3, half-maximal inhibitory concentration: > 20000 nM
Compound 3: no number, only a limit; the forecaster's own chance of this, stated with the estimate: 85%; the middle value lies beyond the limit too.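

In this assay compound 3 gives > 20000 nM, a limit and not a number. Within the data shown here, no step from compound 1 or compound 2 to compound 3 can therefore be read: the limit of > 20000 nM in this assay, at which 3 of the 3 values shown sit. The compounds shown leave open whether either change, methyl in place of hydrogen or thiophen-2-yl in place of furan-3-yl, alters potency at all.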